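This account rests on a few compounds, and the source may have more. Where it says the series, first, only, none or still open, it means among the compounds named here.

Measured compounds in a functional assay on HT-29 cells (Homo sapiens) for antiproliferative activity, with a stated time of 72 h; on this read-out higher numbers stand for weaker inhibition and lower numbers for stronger inhibition:
compound 1 `COc1ccc(C2CC(c3ccc(Cl)cc3)=NN2c2nc(-c3ccccc3)c(C#N)c(=O)n2C)cc1` gives 9120 nM
compound 2 `COc1ccc(C2=NN(c3nc(-c4ccccc4)c(C#N)c(=O)n3C)C(c3ccc(OC)cc3)C2)cc1` gives 9420 nM
compound 3 `Cn1c(N2N=C(c3ccccc3)CC2c2ccc(Cl)cc2)nc(-c2ccc(Cl)cc2)c(C#N)c1=O` gives 15000 nM

Compound 1 and compound 2 differ in one place only, (methoxy in place of chloro on an aromatic carbon), and the step across that change is a 1.0-fold higher number from compound 1 to compound 2 (0.01 log units; within the scatter). All three values lie within the usual scatter of one another, so no order among them is claimed.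

Compound 3 and compound 1 differ in more than one place; the difference between the two cores is not broken down here. Compound 4 `COc1ccc(C2CC(c3ccccc3)=NN2c2nc(-c3ccc(Cl)cc3)c(C#N)c(=O)n2C)cc1` is not yet measured. It differs from compound 3 by methoxy in place of chloro on an aromatic carbon, and the place of the change reads the same, word for word, as the place of the change from compound 1 to compound 2, so this is the same change, made a second time, on the core of compound 3 rather than the core of compound 1. The change occurs twice among these compounds, once measured and once not.

Among the compounds with values here, the expectation for compound 4 rests on the single measured instance: because a 1.0-fold higher number from compound 1 to compound 2 (0.01 log units; within the scatter) stayed within the scatter, the same change on the core of compound 3 is expected to do the same. For compound 4 the expected step in this assay is no change at the digits printed from compound 3 to compound 4 (within the scatter). Within the data shown here, compound 4 is thus estimated at 15000 nM, with a likely range from 7000 nM to 32000 nM, the width reflecting that only one prior instance of the change is available and that the two cores are not compared in detail.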

Compound 4, half-maximal inhibitory concentration: 11000 nM
Compound 4: the middle estimate sits 1.4-fold (0.13 log units) above what was measured; the range from low to high includes it.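

In this assay, methoxy in place of chloro on an aromatic carbon gives a 1.4-fold lower number from compound 3 to compound 4 (0.13 log units; within the scatter), so on this second core the change of 4-chlorophenyl to 4-methoxyphenyl again stays within the scatter. This supports only a narrow statement: on these two cores, the change carries over as a step too small to read, and no direction of effect can be assigned to it on either core. It does not show that the change would be equally silent on any other core, it rests on only two instances, and it gives no reason for the result, but the two steps themselves do not differ in any readable way: the same change on two cores in this assay, a 1.0-fold higher number (0.01 log units; within the scatter) from compound 1 to compound 2 and a 1.4-fold lower number (0.13 log units; within the scatter) from compound 3 to compound 4, 1.4-fold (0.15 log units) apart, within the scatter of two such steps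

The compounds shown leave open whether a different kind of group in the same place on the aromatic ring, such as an amine, a carboxylic acid or a longer chain, would produce a step beyond the scatter. Also open, on these data alone, is whether the pair of cores seen here is representative of the series, since agreement between two steps that both lie within the scatter says little about a change that might produce a larger step elsewhere.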